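This account rests on a few compounds, and the source may have more. Where it says the series, first, only, none or still open, it means among the compounds named here.

The compounds measured so far in an assay on isolated protein for inhibition of histone deacetylase 8 (Homo sapiens), read by mobility shift assay; a lower number here means a stronger inhibitor, a higher number a weaker inhibitor:

Compound 1, `O=C(NO)c1ccc(CN(Cc2ccc(F)cc2)S(=O)(=O)c2c(F)c(F)c(F)c(F)c2F)cc1`, gives 367 nM.
Compound 2, `O=C(NO)c1ccc(CN(Cc2ccc(C(F)(F)F)cc2)S(=O)(=O)c2c(F)c(F)c(F)c(F)c2F)cc1`, gives only a limit of the assay, > 1000 nM.
Compound 3, `CC(C)(C)c1ccc(CN(Cc2ccc(C(=O)NO)cc2)S(=O)(=O)c2c(F)c(F)c(F)c(F)c2F)cc1`, gives 68 nM.

Among the values that are actual numbers, compound 1 stands highest, that is, it is the weaker inhibitor of the two; the gap is a 5.4-fold lower number from compound 1 to compound 3 (0.73 log units; beyond the scatter). Compound 2 sits at a limit, (the limit of > 1000 nM in this assay, at which 1 of the 3 values shown sits), so only a bound is known for it.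

Compound 4, `O=C(NO)c1ccc(CN(Cc2ccncc2)S(=O)(=O)c2c(F)c(F)c(F)c(F)c2F)cc1`, differs from compound 1 by pyridin-4-yl in place of 4-fluorophenyl on a saturated chain carbon bound to a sulfonamide nitrogen. Among the measured compounds shown here, no measured step makes this exact change. The two steps that start from compound 1 alter the same outer ring at the same carbon, and both move the number beyond the scatter: an at least 2.7-fold higher number from compound 1 to compound 2 (0.43 log units; beyond the scatter), and a 5.4-fold lower number from compound 1 to compound 3 (0.73 log units; beyond the scatter). For the measured compounds named here, the number in this assay therefore responds clearly to what sits on that ring, in either direction, but none of the measured compounds carries a ring nitrogen there, so the direction for compound 4 cannot be read off. The expectation is a modest step toward a higher number, a 2.2-fold higher number from compound 1 to compound 4 (0.34 log units; beyond the scatter), with wide uncertainty. Compound 4 is thus estimated at 800 nM, within a range of 250 nM to 3000 nM.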

Compound 4, half-maximal inhibitory concentration: > 1000 nM
Compound 4: only a limit was reported; the forecaster's own chance of this, stated with the estimate: 40%; middle value at least 1.2-fold (0.09 log units) away from the limit.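

In this assay, pyridin-4-yl in place of 4-fluorophenyl on a saturated chain carbon bound to a sulfonamide nitrogen gives an at least 2.7-fold higher number from compound 1 to compound 4 (0.43 log units; beyond the scatter), so altering the ring itself, and not only the group it carries, also moves the number beyond the scatter, here toward weaker inhibition. The gap to the best compound shown is wider still, at an at least 14-fold higher number from compound 3 to compound 4 (1.16 log units; beyond the scatter), which means that a 4-(tert-butyl)phenyl group at this place and a pyridin-4-yl group there lie far apart in this assay. The value of compound 4 is a limit and not a number, so how weak it really is stays unknown, and it now shares that limit with one other compound: the limit of > 1000 nM in this assay, at which 2 of the 4 values shown sit.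

Compound 2 also stands at a limit, so the step between compound 2 and compound 4 cannot be read, and neither can be ranked against the other. From the compounds shown here alone, this change also removes the fluoro group and brings in the ring nitrogen in one move, so the share of each stays open, and a plain phenyl group or a 4-methoxyphenyl group at this place would be needed to separate them.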